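The source may report more compounds than this note shows. Statements on the series, on what has been measured and on what is new or still open speak of the compounds shown alone.

Three measured compounds share one core and differ only in the group carried on a saturated chain carbon bound to an oxygen on a saturated carbon. In an assay on CHO cells for binding affinity to metabotropic glutamate receptor 2 (Rattus norvegicus) (a higher number here means a weaker inhibitor, a lower number a stronger inhibitor), compound 1 `N[C@]1(C(=O)O)[C@H]2[C@@H](C[C@H]1OCCCc1ccccc1)[C@]2(F)C(=O)O` gives 9.83 nM. Compound 2 `N#Cc1cccc(CO[C@@H]2C[C@@H]3[C@H]([C@]2(N)C(=O)O)[C@@]3(F)C(=O)O)c1` gives 2.94 nM in this assay, and compound 3 `N[C@]1(C(=O)O)[C@H]2[C@@H](C[C@H]1OCc1c(Cl)cccc1Cl)[C@]2(F)C(=O)O` gives 4.3 nM. Compound 3 thus stands second highest of the three numbers; its nearest neighbour is compound 2, with a 1.5-fold higher number from compound 2 to compound 3 (0.17 log units; within the scatter), while compound 1 lies furthest, with a 2.3-fold lower number from compound 1 to compound 3 (0.36 log units; beyond the scatter). Compound 4 `N[C@]1(C(=O)O)[C@H]2[C@@H](C[C@H]1OCc1ccc(F)c(Cl)c1)[C@]2(F)C(=O)O` arises from compound 3 by one change: 3-chloro-4-fluorophenyl in place of 2,6-dichlorophenyl on a saturated chain carbon bound to an oxygen on a saturated carbon. Within the data shown here, the measured step that bears on this exchange of one aromatic group for another is the one from compound 2 to compound 3, which was a 1.5-fold higher number from compound 2 to compound 3 (0.17 log units; within the scatter); the larger steps of a 3.3-fold lower number from compound 1 to compound 2 (0.52 log units; beyond the scatter) and a 2.3-fold lower number from compound 1 to compound 3 (0.36 log units; beyond the scatter) concern the phenethyl chain and are less pertinent. Compound 4 is therefore expected to show no step beyond the scatter, with a 1.1-fold lower number from compound 3 to compound 4 (0.03 log units; within the scatter) anticipated. Compound 4 is estimated at 4 nM in this assay, within a range of 1.5 nM to 11 nM.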

Compound 4, inhibition constant: 3.57 nM
Compound 4: the middle estimate sits 1.1-fold (0.05 log units) above what was measured; low and high end bracket the measured number.
By their numbers in this assay, from the lowest: compounds 2, 4 and 3 (each within the scatter of the next); then compound 1.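

In this assay, a 3-chloro-4-fluorophenyl in place of 2,6-dichlorophenyl on this saturated chain carbon leaves the number unchanged within the scatter, with a 1.2-fold lower number from compound 3 to compound 4 (0.08 log units; within the scatter), and the same holds against 3-cyanophenyl, with a 1.2-fold higher number from compound 2 to compound 4 (0.08 log units; within the scatter). The three substituted phenyl groups of compound 2, compound 3 and compound 4 thus cannot be told apart at this position, and the new group also stands clear of phenethyl, with a 2.8-fold lower number from compound 1 to compound 4 (0.44 log units; beyond the scatter), so that among these four compounds only compound 1 stands apart. No measurement at hand accounts for this sameness.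

As far as these compounds go, it remains open whether a phenyl ring carrying an amine or a carboxylic acid would stay with these three numbers. Compound 1 also differs from the others in both its longer chain and its unsubstituted ring, so a plain phenyl on the same carbon would be needed to separate the two.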